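Swapping an oxetane side chain for an oxolane ring

The source may hold more compounds than are shown below. What is called first, only, known or untested is meant among the compounds shown, and "the series" means these compounds.

Measured so far in an assay on isolated protein for inhibition of Leucine-rich repeat serine/threonine-protein kinase 2 (Homo sapiens), read by TR-FRET and LanthaScreen, with stated times of 50 min and 30 min, in the presence of a further agent that is not named here; on this read-out lower numbers stand for stronger inhibition and higher numbers for weaker inhibition:
compound 1 `Cc1c(Nc2nc(N)c3c(C#N)c(N4CCC[C@H]4C)n(C)c3n2)cnn1[C@H]1CCOC1` gives 23 nM
compound 2 `Cc1c(Nc2nc(N)c3c(C#N)c(N4CCC[C@H]4C)n(C)c3n2)cnn1CC1(O)COC1` gives 16 nM
compound 3 `C[C@@H]1CCCN1c1[nH]c2ncnc(N)c2c1C#N` gives 166 nM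

Compound 2 has the lowest of these three numbers. Compound 1 sits close to it, within the scatter of the method, while compound 3, which lacks the aminopyrazole side chain altogether, lies well beyond the scatter at a higher number.

The next compound, compound 4 `Cc1c(Nc2nc(N)c3c(C#N)c(N4CCC[C@H]4C)n(C)c3n2)cnn1[C@@H]1CCOC1`, differs from compound 2 in one place: oxolan-3-yl in place of (3-hydroxyoxetan-3-yl)methyl on an aromatic nitrogen. The oxolan-3-yl group is the same ring that compound 1 carries, here with the other handedness at its stereocentre.

Among the compounds with values here, only one measured step bears on this change, and it is the reverse direction of it: a 1.4-fold lower number from compound 1 to compound 2 (0.16 log units; within the scatter). That step stayed within the scatter, so undoing it should also stay within the scatter. Whether the flipped stereocentre adds anything cannot be judged from the compounds in hand.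

The expected outcome for compound 4 is therefore no step beyond the scatter, a 1.6-fold higher number from compound 2 to compound 4 (0.19 log units; within the scatter). Compound 4 is estimated at 25 nM, with a likely range from 10 nM to 70 nM.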

Compound 4, half-maximal inhibitory concentration: 20 nM
For compound 4 the middle estimate is 1.3-fold (0.10 log units) above the measured one, and the stated range covers the measured number.
By their numbers in this assay, from the lowest: compounds 2, 4 and 1 (each within the scatter of the next); then compound 3.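

In this assay, the reverse swap on this aromatic nitrogen now has a direct reading with the other hand of the oxolane ring: a 1.3-fold higher number from compound 2 to compound 4 (0.10 log units; within the scatter). So replacing (3-hydroxyoxetan-3-yl)methyl, which has 1 hydrogen-bond donor and 2 hydrogen-bond acceptors, with oxolan-3-yl, which has 0 donors and 1 acceptor, gives no step beyond the scatter for either hand of the ring. Within the data shown here, the handedness of the ring itself can also be read for the first time, as a 1.2-fold lower number from compound 1 to compound 4 (0.06 log units; within the scatter) shows no separation beyond the scatter in a pair that isolates this one feature: the fact that compounds 1 and 4 differ only in the configuration as drawn.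

Across these three groups, then, the number at this position stays within the scatter, but all three are oxygen-containing saturated rings of similar size, so the compounds shown leave open whether a piperidine ring, a carboxylic acid or a plain methyl group on this nitrogen would do the same. They also leave open whether the closeness of compounds 1, 2 and 4 would carry over to a read-out in living cells rather than on isolated protein.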